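Swapping acetyl for methyl on the ring amine of compound 2

A few compounds are considered here, and "the series" means these few. Any claim that something is new, unique, unknown or untested is made for them only; others in the source may bear on it.

Compound 1 `CC(=O)N1CCN(c2ccc(Nc3ncc(Cl)c(Nc4ccccc4-c4ncn(C(C)C)n4)n3)cc2)CC1`: 11.2 mL/min/kg
Compound 2 `CC(=O)N1CCc2ccc(Nc3ncc(Cl)c(Nc4ccccc4S(=O)(=O)N(C)C)n3)cc2C1`: 953 mL/min/kg
Compound 3 `CN1CCC(Oc2ccc(Nc3ncc(Cl)c(Nc4ccccc4-c4nnn(C)n4)n3)cc2)CC1`: 48 mL/min/kg

In an ADME assay on microsomes from liver (Homo sapiens) for metabolic stability, read by LC-MS, using NADPH, with stated times of 10 min and 60 min (on this read-out lower numbers stand for slow clearance and higher numbers for fast clearance), compound 2 gives the highest number of the three, standing beyond the scatter from both compound 3 and compound 1. Compound 4 `CN1CCc2ccc(Nc3ncc(Cl)c(Nc4ccccc4S(=O)(=O)N(C)C)n3)cc2C1` differs from compound 2 in one place: methyl in place of acetyl on an amine nitrogen in a ring. Going by the values given here, no step between measured compounds changes this same group, so the data give no direct guide. Compound 4 is expected to stay close to compound 2, with a step of a 1.6-fold lower number from compound 2 to compound 4 (0.20 log units; within the scatter) that may fall within the scatter or run somewhat lower. For compound 4 the estimate in this assay is 600 mL/min/kg, in a range from 200 mL/min/kg to 1500 mL/min/kg.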

Compound 4, clearance: 720 mL/min/kg
Compound 4: middle estimate off by 1.2-fold (0.08 log units), on the low side; measured number inside the range.
By their numbers in this assay, from the lowest: compound 1; then compound 3; then compounds 4 and 2 (each within the scatter of the next).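

In this assay, going by these compounds alone, methyl in place of acetyl on the amine nitrogen in the ring gives a 1.3-fold lower number from compound 2 to compound 4 (0.12 log units; within the scatter), the first step at this position. The swap therefore removes the carbonyl oxygen, a hydrogen-bond acceptor, without a change that can be told from the scatter, and compound 4 stays as fast-cleared as compound 2. No measurement offered here bears on why clearance is so high in this pair. From the compounds shown here alone, whether a hydroxyethyl chain or a carboxylic acid on this nitrogen would give a step beyond the scatter remains open, as does whether the same swap would behave alike on another core.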